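The compounds below may be only part of what the source reports. "The series", "measured", "known", "first", "only" and "open" are said of these compounds alone.

Measured compounds in a functional assay on A549 cells (Homo sapiens) for antiproliferative activity, read by MTT assay, with a stated time of 72 h; a lower number here means a stronger inhibitor, a higher number a weaker inhibitor:
- compound 1, `NS(=O)(=O)c1ccc(NC(=S)Nc2ccc3ncnc(Nc4ccc(F)c(Cl)c4)c3c2)cc1`: > 40000 nM
- compound 2, `NS(=O)(=O)c1ccc(NC(=S)Nc2ccc3ncnc(Nc4ccc(Cl)c(C(F)(F)F)c4)c3c2)cc1`: 4500 nM
- compound 3, `NS(=O)(=O)c1ccc(NC(=S)Nc2ccc3ncnc(Nc4cccc(Cl)c4)c3c2)cc1`: > 40000 nM

Compound 1 sits at a limit of this assay, not at a number. Compound 3 also sits at that limit, as noted in the limit of > 40000 nM in this assay, at which 2 of the 3 values shown sit. Only compound 2 gives a number, and the step of an at least 8.8-fold higher number from compound 2 to compound 3 (0.94 log units; beyond the scatter) is read against the limit of compound 3, so its full size is not known. The step of an at least 8.8-fold lower number from compound 1 to compound 2 (0.94 log units; beyond the scatter) likewise runs from a limit to a number. The pair compound 1 to compound 3 gives a step that the two limits leave unreadable from compound 1 to compound 3, since both values are limits.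

Compound 4, `NS(=O)(=O)c1ccc(NC(=S)Nc2ccc3ncnc(Nc4ccc(OCc5cccc(F)c5)c(Cl)c4)c3c2)cc1`, differs from compound 3 by (3-fluorobenzyl)oxy in place of hydrogen on an aromatic carbon. Within the data shown here, no measured step adds a group of this kind; the closest evidence is that changes on the same ring in compound 3, as in an at least 8.8-fold higher number from compound 2 to compound 3 (0.94 log units; beyond the scatter), move the number by at least a modest amount. From that, a lower number than the limit of compound 3 is expected for compound 4, but with wide uncertainty, the expected step being an at least 6.6-fold lower number from compound 3 to compound 4 (0.82 log units; beyond the scatter). Compound 4 is estimated at 6000 nM, within 1500 nM to 40000 nM.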

Compound 4, half-maximal inhibitory concentration: > 40000 nM
Compound 4: a limit, no number; the forecaster's own chance of this, stated with the estimate: 30%; at least 6.6-fold (0.82 log units) between middle value and limit.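

In this assay compound 4 gives > 40000 nM, a limit and not a number. Compound 4 pairs only with compound 1 and compound 3, which also sit at a limit, so no new step can be read: the limit of > 40000 nM in this assay, at which 3 of the 4 values shown sit.

The compounds shown leave open whether (3-fluorobenzyl)oxy in place of hydrogen on an aromatic carbon moves the number at all.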